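The source may hold more compounds than are shown below. What is called first, only, known or untested is meant among the compounds shown, and "the series" means these compounds.

Values in an ADME assay on Vero cells (Chlorocebus sabaeus) for cytotoxicity, read by resazurin assay, with a stated time of 72 h; a lower number here means that less compound is tolerated, a higher number that more compound is tolerated
Compound 1 `CC(=O)OC[C@H]1O[C@@H](CC(=O)CC2(O)C(=O)N(Cc3ccc(Br)cc3)c3ccc(Cl)cc32)[C@H](OC(C)=O)[C@@H](OC(C)=O)[C@@H]1OC(C)=O` gives "not determined" (no result reported)
Compound 2 `CCCCN1C(=O)/C(=C\C(=O)C[C@@H]2O[C@H](COC(C)=O)[C@@H](OC(C)=O)[C@H](OC(C)=O)[C@H]2OC(C)=O)c2ccccc21` gives 126000 nM
Compound 3 `CCCCN1C(=O)/C(=C\C(=O)C[C@@H]2O[C@H](COC(C)=O)[C@@H](OC(C)=O)[C@H](OC(C)=O)[C@H]2OC(C)=O)c2cc(Cl)ccc21` gives 88900 nM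

Compound 3 at 88900 nM lies within the scatter of compound 2 at 126000 nM and compound 1 offers no number to compare. Compound 4 `CC(=O)OC[C@H]1O[C@@H](CC(=O)/C=C2\C(=O)Nc3ccc(Cl)cc32)[C@H](OC(C)=O)[C@@H](OC(C)=O)[C@@H]1OC(C)=O` has hydrogen in place of butyl on an amide-type nitrogen in a ring. Within the data shown here, the only measured step (a 1.4-fold lower number from compound 2 to compound 3 (0.15 log units; within the scatter)) is a different change, chloro in place of hydrogen on an aromatic carbon, and it stayed within the scatter. Among the measured compounds shown here, no measured pair shows what losing butyl does in this assay so no shift beyond the scatter is expected in either direction. The estimate amounts to a 1.3-fold higher number from compound 3 to compound 4 (0.13 log units; within the scatter) and its uncertainty stays wide. Compound 4 is expected at 120000 nM (estimated range 50000 nM to 290000 nM).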

Compound 4, half-maximal cytotoxic concentration: 122000 nM
Compound 4: middle estimate off by 1.0-fold (0.01 log units), on the low side; the range from low to high includes it.
By their numbers in this assay, from the lowest: compounds 3, 4 and 2 (each within the scatter of the next).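

In this assay the swap of butyl for hydrogen on the amide-type nitrogen in a ring gives a 1.4-fold higher number from compound 3 to compound 4 (0.14 log units; within the scatter) and stays within the scatter. Among these compounds, compounds 2 and 3 both carry butyl there, so this is the first measured sign that cell tolerance holds with or without that chain. No measurement at hand explains this result.

As far as these compounds go, the step was read only with the chloro group present, so its size without chloro remains open. From the compounds shown here alone, a longer chain such as octyl, or a chain ending in an amine, on this nitrogen also remains untested here.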